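The source may hold more compounds than are shown below. What is called first, only, known or untested is meant among the compounds shown, and "the series" means these compounds.

Measured compounds in a functional assay on COLO 205 cells (Homo sapiens) for cytotoxicity, read by MTT assay, with a stated time of 24 h; a higher number here means a weaker inhibitor, a lower number a stronger inhibitor:
Compound 1, `CCCCCCCCCCn1cc(-c2nc3ccccc3cc2C)nn1`, gives 44.5 ug/mL.
Compound 2, `CCCCCCCCCCn1cc(-c2nc3ccccc3cc2CC)nn1`, reaches only > 100 ug/mL, which is a limit of the assay and not a number.
Compound 3, `CCc1cc2ccccc2nc1-c1cn(CCC(F)(F)C(F)(F)C(F)(F)C(F)(F)C(F)(F)C(F)(F)C(F)(F)C(F)(F)F)nn1`, gives 95.2 ug/mL.

Compound 1 and compound 2 share a core and differ by methyl in place of hydrogen on a saturated chain carbon bound to an aromatic carbon. That change produced an at least 2.2-fold higher number from compound 1 to compound 2 (0.35 log units; beyond the scatter); since the reading of compound 2 sits at the limit of > 100 ug/mL in this assay, at which 1 of the 3 values shown sits, only the direction and a lower bound of this step are known. Compound 3 carries a different core, and how its core differs from that of compound 1 is not broken down here; in this assay compound 3 gives a higher number than compound 1.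

Compound 4, `CCCc1cc2ccccc2nc1-c1cn(CCC(F)(F)C(F)(F)C(F)(F)C(F)(F)C(F)(F)C(F)(F)C(F)(F)C(F)(F)F)nn1`, is not yet measured. It differs from compound 3 by methyl in place of hydrogen on a saturated chain carbon, two bonds along the chain from an aromatic carbon. This is the same kind of change as from compound 1 to compound 2, though not the same one: there the methyl entered on a saturated chain carbon bound to an aromatic carbon, here on a saturated chain carbon two bonds along the chain from an aromatic carbon. For compound 4 the step of a 1.5-fold higher number from compound 3 to compound 4 (0.17 log units; within the scatter) is expected, resting on the earlier step of an at least 2.2-fold higher number from compound 1 to compound 2 (0.35 log units; beyond the scatter). Compound 4 is therefore estimated at 140 ug/mL.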

Compound 4, half-maximal inhibitory concentration: > 100 ug/mL
Compound 4: a limit, no number; the forecaster's own chance of this, stated with the estimate: 60%; the middle value is on the limit's open side.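

In this assay compound 4 reads > 100 ug/mL, which is a limit of the assay and not a number: the limit of > 100 ug/mL in this assay, at which 2 of the 4 values shown sit. The methyl in place of hydrogen, on a saturated chain carbon two bonds along the chain from an aromatic carbon, gave an at least 1.0-fold higher number from compound 3 to compound 4 (0.02 log units; that floor lies within the scatter), so this floor alone does not establish a real shift on this core. The series therefore shows that both readings are compatible with the change moving the number the same way, but it does not show that the change has the same size on both cores, or that its effect carries over from one core to the other: the same change on two cores in this assay, an at least 2.2-fold higher number (0.35 log units; beyond the scatter) from compound 1 to compound 2 and an at least 1.0-fold higher number (0.02 log units; that floor lies within the scatter) from compound 3 to compound 4; the limit leaves it open whether they differ.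

The compounds shown leave open what the true readings would be for those at the limit, so the size of either step remains unknown. They also leave open how the series would read with an amine, a hydroxyl group or a carboxylic acid at the end of the alkyl chain in place of its last methyl.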